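A Methyl Added to Two Related Acrylamides

This account rests on a few compounds, and the source may have more. Where it says the series, first, only, none or still open, it means among the compounds named here.

Compound 1 `C/C(=C\c1nc(-c2ccccc2)cs1)C(N)=O` and compound 2 `C/C(=C\c1nc(-c2ccc(C)cc2)cs1)C(N)=O` share one core, while compound 3 `C/C(=C\c1cccc(-c2ccccc2)c1)C(N)=O` and compound 4 `C/C(=C\c1cccc(-c2ccc(C)cc2)c1)C(N)=O` share another; how the two cores differ is not broken down here. All were tested in a functional assay on T-24 cells (Homo sapiens) for cytotoxicity, read by CCK-8 assay, with a stated time of 24 h; a lower number here means a stronger inhibitor, a higher number a weaker inhibitor. Compound 1 gives > 50000 nM, which is a limit of the assay rather than a number. Compound 2 gives > 50000 nM, likewise a limit. The change from compound 1 to compound 2 is methyl in place of hydrogen on an aromatic carbon, and its step that the two limits leave unreadable from compound 1 to compound 2 cannot be read because of the limit of > 50000 nM in this assay, at which 3 of the 3 values shown sit. Compound 3 gives > 50000 nM, again a limit. Compound 4 carries the same change on the second core: methyl in place of hydrogen on an aromatic carbon. The expectation rests on compound 3 having given only a limit, > 50000 nM. For compound 4 the step expected is a step that the limit leaves unreadable from compound 3 to compound 4. The estimate for compound 4 is 80000 nM.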

Compound 4, half-maximal inhibitory concentration: 7650 nM
Compound 4: the middle estimate sits 10-fold (1.02 log units) above what was measured; measured number below the stated range.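

In this assay, methyl in place of hydrogen on an aromatic carbon of the second core gives an at least 6.5-fold lower number from compound 3 to compound 4 (0.81 log units; beyond the scatter), so on this core the change moves the result from a limit to a measured number. Compound 2, which carries the same methyl on the first core, gives > 50000 nM, a limit and not a number. This shows no transfer between the two cores, and no failure of transfer either, because the step on the first core cannot be read: the limit of > 50000 nM in this assay, at which 3 of the 4 values shown sit.

Going by these compounds, it remains open how an ethyl group, a methoxy group or a carboxylic acid in the place of that methyl would read on either core. On these data alone, it also remains open how large the step on the second core truly is.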